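A few compounds are considered here, and "the series" means these few. Any claim that something is new, unique, unknown or untested is made for them only; others in the source may bear on it.

Working notes on the series. In a functional assay on Raji cells (Homo sapiens) for cytotoxicity, with a stated time of 72 h (a lower number here means that less compound is needed, a higher number that more compound is needed for the effect), compound 1 `C=C[C@@](C)(/C=C/c1ccc(OS(=O)(=O)C(F)(F)F)cc1)CCC=C(C)C` gives only a limit, > 26000 nM. Compound 2 `C=C[C@@](C)(/C=C/c1ccc(O)cc1)CC/C=C/C(=O)OCC` likewise gives only a limit in this assay, > 26000 nM. Compound 3 `C=C[C@@](C)(/C=C/c1ccc(O)cc1)CC/C=C(\C)C(=O)OCC` also returns a limit in this assay, > 26000 nM. Compound 1 thus stands exactly where every value shown sits: the limit of > 26000 nM in this assay, at which 3 of the 3 values shown sit. Among the measured compounds shown here, no step between measured compounds can be drawn from these values, so no measured step size is available.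

Compound 4 `C=C[C@@](C)(/C=C/c1ccc(Nc2ccc(Cl)c(Cl)c2)cc1)CCC=C(C)C` is not yet measured in this assay. It differs from compound 1 in one place: (3,4-dichlorophenyl)amino in place of ((trifluoromethyl)sulfonyl)oxy on an aromatic carbon. A moderate step toward lower concentration is expected, an at least 2.1-fold lower number from compound 1 to compound 4 (0.33 log units; beyond the scatter). For compound 4 in this assay the estimate is 12000 nM, with a range from 2500 nM to 26000 nM.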

Compound 4, half-maximal effective concentration: > 26000 nM
Compound 4 was reported as a limit; the forecaster's own chance of this, stated with the estimate: 45%; middle value at least 2.1-fold (0.33 log units) from the limit.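

Compound 4 also returns only a limit in this assay, > 26000 nM, so the step from compound 1 to this compound cannot be read. The compounds shown leave open which structural change, if any, would give a measurable value, with every compound at the same point: the limit of > 26000 nM in this assay, at which 4 of the 4 values shown sit.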